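The compounds below may be only part of what the source reports. "The series", "measured", "known", "first", "only" and "open" are said of these compounds alone.

Three measured compounds share one core. Compound 1 `O=C1c2c[n+]([O-])c3ccccc3c2C(=O)c2c1c1ccccc1n2Cc1cn([C@H]2O[C@H](CO)[C@@H](O)[C@H]2O)nn1` gives 1370 nM in a toxicity assay on HEK-293T cells (Homo sapiens) for cytotoxicity, read by MTT assay, with a stated time of 72 h; a higher number here means a weaker inhibitor, a lower number a stronger inhibitor. Compound 2 `O=C1c2c[n+]([O-])c3ccccc3c2C(=O)c2c1c1ccccc1n2Cc1cn(C[C@H](O)CO)nn1` gives 8880 nM in this assay, the highest of the three numbers, while compound 3 `CN1CCN(CCCn2c3c(c4ccccc42)C(=O)c2c[n+]([O-])c4ccccc4c2C3=O)CC1` gives 170 nM. The two measured steps are a 6.5-fold higher number from compound 1 to compound 2 (0.81 log units; beyond the scatter) and a 52-fold lower number from compound 2 to compound 3 (1.72 log units; beyond the scatter). Compound 4 `O=C1c2c[n+]([O-])c3ccccc3c2C(=O)c2c1c1ccccc1n2Cc1cn(C[C@@H](O)CO)nn1` is the counterpart of compound 2 with one difference: the two compounds have the same atoms and bonds and differ only in configuration as drawn: 1 of 1 stereo elements differ; a stereocentre at a saturated chain carbon is drawn S in compound 2 and R in compound 4. Among the compounds with values here, neither measured step concerns configuration alone; both exchange one group for another, so no measured step bears directly on this change. The expected step is a 1.0-fold higher number from compound 2 to compound 4 (0.00 log units; within the scatter), which lies within the scatter. For compound 4 in this assay the estimate is 8900 nM, with a range from 3500 nM to 22000 nM.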

Compound 4, half-maximal inhibitory concentration: 2030 nM
The estimate for compound 4 lay 4.4-fold (0.64 log units) above the measured number, and the stated range ends above it.
By their numbers in this assay, from the lowest: compound 3; then compounds 1 and 4 (each within the scatter of the next); then compound 2.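

In this assay, the configuration at this saturated chain carbon alone shifts the number beyond the scatter, a 4.4-fold lower number from compound 2 to compound 4 (0.64 log units; beyond the scatter), whereas both earlier steps exchanged one group for another. The shift can be assigned to this stereocentre because nothing else changes: the fact that compounds 2 and 4 differ only in the configuration as drawn. With the R configuration, exchanging 3,4-dihydroxy-5-(hydroxymethyl)oxolan-2-yl for 2,3-dihydroxypropyl stays within the scatter, a 1.5-fold higher number from compound 1 to compound 4 (0.17 log units; within the scatter), while the exchange involving 2-(4-methylpiperazin-1-yl)ethyl remains large, a 12-fold higher number from compound 3 to compound 4 (1.08 log units; beyond the scatter).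

The compounds shown leave open whether the two configurations would still differ if a carboxylic acid or a primary amine replaced the hydroxyl groups on this chain.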